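Two-ring replacements at the aryl group, and a third to weigh

This account rests on a few compounds, and the source may have more. Where it says the series, first, only, none or still open, it means among the compounds named here.

Of the compounds shown here, three sharing one core have been measured in a functional assay on MCF7 cells (Homo sapiens) for inhibition; on this read-out higher numbers stand for weaker inhibition and lower numbers for stronger inhibition. Compound 1 `CC/C(=C(/c1ccc(/C=C/C(=O)O)cc1)c1cc2ccccc2[nH]1)c1ccc(C#N)cc1` gives 278 nM. Compound 2 `CC/C(=C(/c1ccc(/C=C/C(=O)O)cc1)c1cc2ccccc2[nH]1)c1ccc(C(F)(F)F)cc1Cl` gives 27 nM, and compound 3 `CC/C(=C(/c1ccc(/C=C/C(=O)O)cc1)c1cc2ccccc2[nH]1)c1ccc(Cl)cc1C#N` gives 14 nM. Compound 1 therefore stands highest of the three numbers, with a 10-fold lower number from compound 1 to compound 2 (1.01 log units; beyond the scatter) and a 20-fold lower number from compound 1 to compound 3 (1.30 log units; beyond the scatter), while a 1.9-fold lower number from compound 2 to compound 3 (0.29 log units; within the scatter).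

Compound 4 `CC/C(=C(/c1ccc(/C=C/C(=O)O)cc1)c1cc2ccccc2[nH]1)c1cc(Cl)ccc1Cl` has not yet been measured in this assay. It differs from compound 1 in one place: 2,5-dichlorophenyl in place of 4-cyanophenyl on a double-bonded chain carbon bound to a double-bonded chain carbon and a saturated chain carbon. The two measured steps that start from compound 1 both remove the same 4-cyanophenyl and both bring in a ring carrying a chloro substituent, and both produced large falls in the number: a 10-fold lower number from compound 1 to compound 2 (1.01 log units; beyond the scatter) and a 20-fold lower number from compound 1 to compound 3 (1.30 log units; beyond the scatter). The 2,5-dichlorophenyl of compound 4 again carries a chlorine on the ring, so a fall of comparable size is expected, beyond the scatter, rather than no change. Because a 20-fold lower number from compound 1 to compound 3 (1.30 log units; beyond the scatter) was somewhat larger than a 10-fold lower number from compound 1 to compound 2 (1.01 log units; beyond the scatter), the size of the fall is uncertain within that span. Compound 4 is estimated at 30 nM, in a range from 10 nM to 90 nM, which would mean an expected step of a 9.3-fold lower number from compound 1 to compound 4 (0.97 log units; beyond the scatter).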

Compound 4, half-maximal inhibitory concentration: 71 nM
Compound 4: middle estimate off by 2.4-fold (0.37 log units), on the low side, within the range that was stated.
By their numbers in this assay, from the lowest: compounds 3 and 2 (each within the scatter of the next); then compound 4; then compound 1.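

Moving from 4-cyanophenyl to 2,5-dichlorophenyl on this double-bonded chain carbon still helps in this assay, with a 3.9-fold lower number from compound 1 to compound 4 (0.59 log units; beyond the scatter), but the modest size of this step shows that a chlorine-bearing ring does not by itself reproduce the large falls seen earlier. The three replacement rings also separate at this position, since both a 5.1-fold higher number from compound 3 to compound 4 (0.71 log units; beyond the scatter) and a 2.6-fold higher number from compound 2 to compound 4 (0.42 log units; beyond the scatter) lie beyond the scatter, even though each of the three rings carries chlorine; what compounds 2 and 3 gain over compound 1 is therefore tied to the particular ring and not to chlorine alone. No measurement offered here bears on why 2,5-dichlorophenyl falls short of the other two rings.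

The rings compared differ from one another in more than one substituent, so these steps cannot assign the gap to any single group. From the compounds shown here alone, it remains open whether a 4-chlorophenyl, or a phenyl carrying a methoxy group or an amine, would stand with compound 4 or with compounds 2 and 3.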